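Swapping the Terminal Phenyl for a Cyclohexyl

A few compounds are considered here, and "the series" means these few. Any claim that something is new, unique, unknown or untested is made for them only; others in the source may bear on it.

Compound 1 `O=C(CCCCCCc1ccccc1)N1CCCC1` is an amide whose saturated chain ends in a phenyl. Among the compounds with values here, in an assay on HEK293 cells for inhibition of N-acylethanolamine-hydrolyzing acid amidase (Rattus norvegicus), read by LC-MS, with a stated time of 30 min (a higher number here means a weaker inhibitor, a lower number a stronger inhibitor), compound 1 gives 12900 nM, the only actual number among the three measured compounds. Compound 2 `O=C(CCCCCCc1ccccc1Cl)N1CCCC1` carries a chloro on that phenyl. In this assay compound 2 reaches only the limit of > 100000 nM. Compound 3 `O=C(O)c1ccc(CCCCCCC(=O)N2CCCC2)cc1` carries a carboxy on the phenyl instead. In this assay compound 3 likewise reaches only the limit of > 100000 nM. Both steps are large: an at least 7.7-fold higher number from compound 1 to compound 2 (0.88 log units; beyond the scatter) and an at least 7.7-fold higher number from compound 1 to compound 3 (0.88 log units; beyond the scatter), each ending at the limit of > 100000 nM in this assay, at which 2 of the 3 values shown sit.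

Compound 4 `O=C(CCCCCCC1CCCCC1)N1CCCC1` differs from compound 1 by cyclohexyl in place of phenyl on a saturated chain carbon, six bonds along the chain from a carbonyl carbon. Neither measured step is the same kind of change: both kept the phenyl and attached a group to it, whereas here the aromatic ring itself is exchanged for a saturated one. They show only that the phenyl end of compound 1 accepts little alteration without the number rising to the limit. An upward step is therefore the likelier direction, though probably smaller than those seen. Compound 4 is expected to give about 25000 nM in this assay, within 6000 nM to 100000 nM. That estimate means an expected step of a 1.9-fold higher number from compound 1 to compound 4 (0.29 log units; within the scatter).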

Compound 4, half-maximal inhibitory concentration: 5700 nM
The estimate for compound 4 lay 4.4-fold (0.64 log units) above the measured number; the whole stated range lies above it.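

The terminal ring of this series need not be aromatic: with cyclohexyl in place of phenyl, six bonds along the chain from a carbonyl carbon, the result is a 2.3-fold lower number from compound 1 to compound 4 (0.35 log units; beyond the scatter). Within the data shown here, this is the first change at the chain end that lowers the number in this assay, so what compound 2 and compound 3 showed applies to attaching a group to the phenyl, not to every change at this end. Compound 2 and compound 3 each remain at a limit, which is not an exact number: the limit of > 100000 nM in this assay, at which 2 of the 4 values shown sit.

The compounds shown leave open whether a chloro or a carboxy on the cyclohexyl would raise the number as it did on the phenyl. They also leave open how a longer chain, a shorter chain or an amine at the chain end would fare.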